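The source may hold more compounds than are shown below. What is called first, only, known or untested is meant among the compounds shown, and "the series" means these compounds.

Compound 1 `CC(C)CCn1ccc(-c2ccc(OCC3CC3)cc2)c(C#N)c1=O`: 290 nM
Compound 2 `CC(C)CCn1ccc(-c2ccc(Oc3ccccn3)cc2)c(C#N)c1=O`: 646 nM
Compound 3 `CC(C)CCn1ccc(-c2ccc(Oc3cccnc3)cc2)c(C#N)c1=O`: 479 nM

In a functional assay on CHO cells for positive allosteric modulation of metabotropic glutamate receptor 2 (Homo sapiens), read by scintillation counting and GTPgammaS binding, with a stated time of 30 min (on this read-out lower numbers stand for an effect already at smaller amounts and higher numbers for an effect only at larger amounts of compound), compound 3 stands second highest of the three numbers, and all three sit close together: a 1.7-fold higher number from compound 1 to compound 3 (0.22 log units; within the scatter) and a 1.3-fold lower number from compound 2 to compound 3 (0.13 log units; within the scatter) both lie within the scatter, while a 2.2-fold higher number from compound 1 to compound 2 (0.35 log units; beyond the scatter) is a modest step beyond it. Compound 4 `CNc1ccc(-c2ccn(CCC(C)C)c(=O)c2C#N)cc1` carries methylamino in place of (pyridin-3-yl)oxy on an aromatic carbon. Among the measured compounds shown here, none of the measured steps bears directly on this kind of change; each of them only exchanged one group on the ether oxygen for another, and all of them stayed small. The step of a 1.7-fold higher number from compound 3 to compound 4 (0.22 log units; within the scatter) is therefore expected to be uncertain in direction, with a range wider than the measured spread. Compound 4 is estimated at 800 nM, between 250 nM and 2500 nM in this assay.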

Compound 4, half-maximal effective concentration: 460 nM
Compound 4: middle estimate off by 1.7-fold (0.24 log units), on the high side, within the range that was stated.
By their numbers in this assay, from the lowest: compounds 1, 4, 3 and 2 (each within the scatter of the next, the first and the last beyond it).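

Swapping the ring-bearing ether for methylamino, a far smaller group with no ring and a hydrogen-bond donor, moves the number very little: a 1.0-fold lower number from compound 3 to compound 4 (0.02 log units; within the scatter) and a 1.4-fold lower number from compound 2 to compound 4 (0.15 log units; within the scatter) and a 1.6-fold higher number from compound 1 to compound 4 (0.20 log units; within the scatter) all lie within the scatter. In this assay this aromatic carbon, para to a large group, therefore accepts a nitrogen link as readily as an oxygen link, and no ring on the substituent is needed among these compounds. No evidence is given that explains this tolerance. On these data alone, whether an unsubstituted amine, dimethylamino or a carboxylic acid on this carbon would fit equally well stays open. So does the effect of a longer chain on the nitrogen.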